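Two measured pyranochromenones and a halogen swap

This account rests on a few compounds, and the source may have more. Where it says the series, first, only, none or still open, it means among the compounds named here.

Measured so far:
- compound 1, `Cc1cc(=O)c2c(O)c(CN3CC(O)CC3C(=O)O)c(O)c([C@H]3CCN(C)C[C@H]3O)c2o1`: 23%
- compound 2, `Cc1oc2c([C@H]3CCN(C)C[C@H]3O)c(O)cc(O)c2c(=O)c1C(O)c1cccc(Cl)c1`: 2%

In a functional assay on MIA PaCa-2 cells (Homo sapiens) for inhibition, read by MTT assay, with a stated time of 48 h, tested at 10 uM (a lower number here means less inhibition of growth, a higher number more inhibition of growth at the concentration tested), compound 1 gives 23%, while compound 2 gives 2%. Compound 2 therefore stands lowest of the two numbers; its nearest neighbour, compound 1, lies higher by a margin beyond the scatter. The two compounds differ in more than one place, so nothing is said here beyond what their two values show.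

Compound 3, `Cc1oc2c([C@H]3CCN(C)C[C@H]3O)c(O)cc(O)c2c(=O)c1C(O)c1ccc(F)cc1`, has not yet been measured in this assay. It differs from compound 2 by one exchange: 4-fluorophenyl in place of 3-chlorophenyl on a saturated chain carbon bound to an aromatic carbon and an oxygen on a saturated carbon. Among the compounds with values here, no single-point step between measured compounds is available to set the size of such a change. The group that leaves and the group that enters are counted alike, so the expected step of a number 3 percentage points higher from compound 2 to compound 3 (within the scatter) is small, with no clear direction and probably none beyond the scatter. Compound 3 is thus estimated at 5% in this assay, within a range from -8% to 20%.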

Compound 3, percent growth inhibition at one concentration: 17%
Compound 3: middle estimate off by 12 percentage points, on the low side, and the stated range covers the measured number.
By their numbers in this assay, from the lowest: compound 2; then compounds 3 and 1 (each within the scatter of the next).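

In this assay, within the data shown here, the aryl group on a saturated chain carbon bound to an aromatic carbon and an oxygen on a saturated carbon proves able to move the reading, with a number 15 percentage points higher from compound 2 to compound 3 (beyond the scatter) for 4-fluorophenyl in place of 3-chlorophenyl, and this is the first single-place step. The two groups count alike in heavy atoms, hydrogen-bond donors and hydrogen-bond acceptors, so the step comes from a difference that those counts do not register. Nothing measured here accounts for it.

The halogen and its place on the ring change together in this one step, and the compounds shown cannot separate the two. On these data alone, how the reading responds at this carbon to a phenyl without any halogen, to a methoxyphenyl or to a pyridyl ring also remains open.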